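Methoxy to hydroxy at the weak end of the series

The source may hold more compounds than are shown below. What is called first, only, known or untested is meant among the compounds shown, and "the series" means these compounds.

In a functional assay on MCF7 cells (Homo sapiens) for cytotoxicity (a higher number here means a weaker inhibitor, a lower number a stronger inhibitor), compound 1 (structure `COc1c(O)cc2c3c1C[C@@H](C)C[C@H](OC)[C@H](O3)[C@@H](C)/C=C(\C)[C@H](OC(N)=O)[C@@H](OC)C[C@@H](O)/C=C(\C)C(=O)N2`) gives > 100000 nM as a limit of the assay, not a number. Compound 2 (structure `COc1c(O)cc2c3c1C[C@@H](C)C[C@H](OC)[C@H](O3)[C@@H](C)/C=C(\C)[C@H](OC(N)=O)[C@@H](OC)/C=C/C=C(\C)C(=O)N2`) gives 36000 nM in the same read-out. Compound 3 (structure `COc1c(O)cc2cc1C[C@@H](C)C[C@H](OC)[C@H](O)[C@@H](C)/C=C(\C)[C@H](OC(N)=O)[C@@H](OC)CC/C=C(\C)C(=O)N2`) has no single number, and its result stands as "not active" (no number reported) in these notes. Compound 4 (structure `CO[C@H]1C[C@H](C)Cc2cc(cc(O)c2O)NC(=O)/C(C)=C/CC[C@H](OC)[C@@H](OC(N)=O)/C(C)=C/[C@H](C)[C@H]1O`) is still unmeasured. The change is hydrogen in place of methyl on an oxygen on an aromatic ring and amounts to hydrogen in place of methyl on an oxygen on an aromatic ring, methoxy to hydroxy. Without a number for compound 3, no step size can be read, but a small gain in this assay is expected, leaving the result weak and close to compound 2 at 36000 nM on this scale. Compound 4 is estimated at 40000 nM with an expected range from 8000 nM to 100000 nM in this read-out.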

Compound 4, half-maximal inhibitory concentration: "not active" (no number reported)
For compound 4 the study gives words and no number; no gap can be computed for the estimate.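

No new step can be read between compound 3 and compound 4: both stand as "not active", with no number reported. The compounds shown leave open how far methoxy to hydroxy shifts cytotoxicity on this shared core, if at all.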